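The compounds below may be only part of what the source reports. "The series", "measured", "known", "first", "only" and "open" are said of these compounds alone.

In a functional assay on K562 cells (Homo sapiens) for inhibition, read by trypan blue exclusion, with a stated time of 72 h (a lower number here means a stronger inhibitor, a higher number a weaker inhibitor), two compounds have been measured so far. Compound 1 (`Cn1c(=O)c(S(=O)(=O)c2ccc(F)cc2F)cc2cnc(Nc3cccc4[nH]ccc34)nc21`) gives 1500 nM, and compound 2 (`Cn1c(=O)c(S(=O)(=O)c2ccc(F)cc2)cc2cnc(Nc3ccc4[nH]cnc4c3)nc21`) gives 10000 nM. Compound 2 therefore holds the higher of the two numbers, making it the weaker inhibitor of the pair, and the gap between them lies beyond the usual scatter of repeated measurements. These two compounds differ in more than one place, so their gap cannot be assigned to any single group.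

Compound 3 (`Cn1c(=O)c(S(=O)(=O)c2ccc(F)cc2)cc2cnc(Nc3cccc4[nH]ccc34)nc21`) has not yet been measured. It departs from compound 2 in one place: 1H-indol-4-yl in place of 1H-benzimidazol-5-yl on a nitrogen on an aromatic ring. Compound 1 also carries 1H-indol-4-yl and gives 1500 nM, so a move to a lower number in this assay is expected, moderate in size and beyond the scatter. The expected change is a 5.0-fold lower number from compound 2 to compound 3 (0.70 log units; beyond the scatter). For compound 3 the estimated value is 2000 nM, with an expected range from 600 nM to 7000 nM.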

Compound 3, half-maximal inhibitory concentration: 750 nM
For compound 3 the middle estimate is 2.7-fold (0.43 log units) above the measured one; the range from low to high includes it.
By their numbers in this assay, from the lowest: compounds 3 and 1 (each within the scatter of the next); then compound 2.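

In this assay, 1H-indol-4-yl in place of 1H-benzimidazol-5-yl on the nitrogen can now be read as a single change, and it gives a 13-fold lower number from compound 2 to compound 3 (1.12 log units; beyond the scatter), a large step showing that this position strongly affects the result. The other change tells a different story: hydrogen in place of fluoro on an aromatic carbon gives a 2.0-fold lower number from compound 1 to compound 3 (0.30 log units; within the scatter), so in this pair, with 1H-indol-4-yl present, that fluoro has no effect that can be told apart from the scatter. The compounds show how large the step at the nitrogen is, but nothing here explains it.

The step at the nitrogen changes two things at once, the ring nitrogen count and the point at which the fused ring system is attached, so the compounds leave open which of these matters. A 1H-indol-5-yl group on the same nitrogen would separate the two, while a plain phenyl ring or a ring bearing a piperazine would show whether the fused five-membered ring is needed at all.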